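A Carboxy Group Added to a Weak Prenyl Protease Inhibitor

This account rests on a few compounds, and the source may have more. Where it says the series, first, only, none or still open, it means among the compounds named here.

Measured compounds:
- compound 1, `N#Cc1ccc(NC(c2ccccc2)c2ccc3cccnc3c2O)cc1`, "not determined" (no result reported)
- compound 2, `Oc1c(C(Nc2ccccc2)c2ccccc2)ccc2ccccc12`, 4900 nM

Going by the values given here, in an assay on isolated protein for inhibition of CAAX prenyl protease 2 (Homo sapiens), with stated times of 60 s and 60 min (on this read-out higher numbers stand for weaker inhibition and lower numbers for stronger inhibition), compound 2 gives 4900 nM, which is the only number in hand; compound 1 was run but no result was reported for it, so nothing can be said about how the two compare. Compound 2 is therefore the sole reference point, and its value places it among weak inhibitors on this read-out.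

Compound 3, `O=C(O)c1ccc(NC(c2ccccc2)c2ccc3ccccc3c2O)cc1`, is the next step. It differs from compound 2 by carboxy in place of hydrogen on an aromatic carbon, sitting para to a large group. Read one bond further out, phenyl becomes 4-carboxyphenyl.

Among the compounds with values here, no measured pair shows what such a change does here, so the expected step from compound 2 to compound 3 rests on that one starting value alone. For compound 3 the step of a 1.3-fold higher number from compound 2 to compound 3 (0.12 log units; within the scatter) is expected to be small, at most slightly toward weaker inhibition. Compound 3 is therefore estimated at 6500 nM, within a range from 1500 nM to 28000 nM.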

Compound 3, half-maximal inhibitory concentration: 4200 nM
Beside the measured number, compound 3's estimate is 1.5-fold (0.19 log units) above it; low and high end bracket the measured number.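

In this assay the change from phenyl to 4-carboxyphenyl gives a 1.2-fold lower number from compound 2 to compound 3 (0.07 log units; within the scatter) and so leaves the two compounds indistinguishable on this read-out. Going by these compounds alone, this is the first measured pair here that differs in one place, and it shows that an aromatic carbon para to a large group can carry carboxy, with its 3 heavy atoms, in place of hydrogen with no measurable change in inhibition, although compound 3, like compound 2, stays a weak inhibitor. No measurement at hand accounts for this flat result.

From the compounds shown here alone, one pair cannot show whether this position is indifferent to substitution in general, so it remains open whether an amine, a methyl ester or a longer chain ending in a carboxylic acid would shift the number beyond the usual scatter. Compound 1 has no reported result and therefore offers no second comparison, which leaves open how a nitrile on this ring would behave and whether any change elsewhere on the shared core would matter more than this one.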